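From furan-2-yl to furan-3-yl on a shared core

A few compounds are considered here, and "the series" means these few. Any claim that something is new, unique, unknown or untested is made for them only; others in the source may bear on it.

In an ADME assay on BJ cells (Homo sapiens) for cytotoxicity, read by MTT assay, with a stated time of 72 h (a lower number here means that less compound is tolerated, a higher number that more compound is tolerated), compound 1 (`OC[C@H]1O[C@@H](n2cc(Cl)c3c(-c4ccc(F)cc4)ncnc32)[C@H](O)[C@@H]1O`) gives 49500 nM and compound 2 (`OC[C@H]1O[C@@H](n2cc(Cl)c3c(-c4ccco4)ncnc32)[C@H](O)[C@@H]1O`) gives 37300 nM as its value, two numbers within the scatter of each other. Compound 3 (`OC[C@H]1O[C@@H](n2cc(Cl)c3c(-c4ccoc4)ncnc32)[C@H](O)[C@@H]1O`) keeps the shared core and carries furan-3-yl in place of furan-2-yl on an aromatic carbon. The two compounds hold the same atoms, joined differently. Going by the values given here, only one measured step bears on this change. It exchanged 4-fluorophenyl for furan-2-yl on the same carbon and stayed within the scatter (a 1.3-fold lower number from compound 1 to compound 2 (0.12 log units; within the scatter)). With so little evidence and a swap that keeps the same kind of ring, no step beyond the scatter is expected in this assay in either direction. The estimated step is a 1.0-fold higher number from compound 2 to compound 3 (0.01 log units; within the scatter) at most a small one. For compound 3 the estimated value is 38000 nM with an expected range from 19000 nM to 75000 nM in this test.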

Compound 3, half-maximal cytotoxic concentration: 21600 nM
The estimate for compound 3 lay 1.8-fold (0.25 log units) above the measured number, within the range that was stated.
By their numbers in this assay, from the lowest: compounds 3, 2 and 1 (each within the scatter of the next, the first and the last beyond it).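

In this assay this position gives its first step beyond the scatter: furan-3-yl in place of 4-fluorophenyl brings a modest drop in the tolerated concentration (a 2.3-fold lower number from compound 1 to compound 3 (0.36 log units; beyond the scatter)). Moving the attachment point of the furan ring alone stays within the scatter (a 1.7-fold lower number from compound 2 to compound 3 (0.24 log units; within the scatter)), so the two furan isomers cannot be told apart here, even though only compound 3 separates from compound 1. Nothing at hand explains either step.

As far as these compounds go, compound 2 lies within the scatter of both compound 1 and compound 3, so it remains open whether the drop belongs to furan-3-yl alone or to furan rings in general. From the compounds shown here alone, how an amine or a longer carbon chain on this carbon, in place of an aromatic ring, would shift the number also stays open.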